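Three-Membered Ring Replaces the Branched Alkene on the Amide

The source may report more compounds than this note shows. Statements on the series, on what has been measured and on what is new or still open speak of the compounds shown alone.

Three amides share one core and differ only in the group attached to the carbonyl carbon. In an assay on LtK cells with ATP-sensitive inward rectifier potassium channel 11 (Homo sapiens) as the target (a lower number here means that less compound is needed, a higher number that more compound is needed for the effect), compound 1 `CCC(=O)Nc1c(C(O)(C(F)(F)F)C(F)(F)F)ccc2ccccc12` gives 15 nM. Compound 2 `CC(C)C(=O)Nc1c(C(O)(C(F)(F)F)C(F)(F)F)ccc2ccccc12` gives 6630 nM, while compound 3 `CC(C)=CC(=O)Nc1c(C(O)(C(F)(F)F)C(F)(F)F)ccc2ccccc12` gives 46 nM. Compound 3 therefore holds the second highest of the three numbers: it sits nearest compound 1, with a 3.1-fold higher number from compound 1 to compound 3 (0.49 log units; beyond the scatter), and furthest from compound 2, with a 140-fold lower number from compound 2 to compound 3 (2.16 log units; beyond the scatter).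

Compound 4 `O=C(Nc1c(C(O)(C(F)(F)F)C(F)(F)F)ccc2ccccc12)C1CC1` has yet to be measured in this assay. Against compound 3 the change is cyclopropyl in place of 2-methylprop-1-en-1-yl on a carbonyl carbon. Among the measured compounds shown here, two measured steps bear on it. A single extra methyl gave a 440-fold higher number from compound 1 to compound 2 (2.65 log units; beyond the scatter), and the move from that branched saturated group to the unsaturated one gave a 140-fold lower number from compound 2 to compound 3 (2.16 log units; beyond the scatter). Cyclopropyl, like isopropyl, presents a carbon bearing two further carbons to the carbonyl, yet it lacks the open-chain branching that accompanied the large jump. The expectation is a modest rise above compound 3, a 3.3-fold higher number from compound 3 to compound 4 (0.51 log units; beyond the scatter), with compound 4 estimated at 150 nM, within 20 nM to 1500 nM.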

Compound 4, half-maximal effective concentration: 751 nM
Beside the measured number, compound 4's estimate is 5.0-fold (0.70 log units) below it, within the range that was stated.
By their numbers in this assay, from the lowest: compound 1; then compound 3; then compound 4; then compound 2.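

In this assay the three-membered ring does not match any of the open-chain groups at this carbonyl carbon: there is a 16-fold higher number from compound 3 to compound 4 (1.21 log units; beyond the scatter) and a 50-fold higher number from compound 1 to compound 4 (1.70 log units; beyond the scatter), yet also an 8.8-fold lower number from compound 2 to compound 4 (0.95 log units; beyond the scatter). The earlier compounds shown here showed only a low and a very high number at this place, whereas compound 4 lands in the range those numbers leave open, so the outcome here is graded rather than all-or-nothing. Tying the two branches of isopropyl into cyclopropyl recovers part of the gap to compound 1, but less than the 2-methylprop-1-en-1-yl group of compound 3 does.

On these data alone, whether a cyclobutyl or tert-butyl group, or a longer chain, on this carbonyl carbon would continue this order remains open. Nothing measured here explains why these groups differ.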